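A few compounds are considered here, and "the series" means these few. Any claim that something is new, unique, unknown or untested is made for them only; others in the source may bear on it.

Compound 3 `CCCCCCCCCCCCOc1ccc2c(=O)c(-c3ccc(O)cc3)coc2c1` carries a long, purely hydrocarbon chain on the oxygen attached to the aromatic ring. In an assay (Cricetulus griseus) for inhibition of aldehyde dehydrogenase, mitochondrial (Homo sapiens) (a higher number here means a weaker inhibitor, a lower number a stronger inhibitor), compound 3 gives > 9000 nM, which is a limit of the assay and not a number. It sits at the limit of > 9000 nM in this assay, at which 1 of the 3 values shown sits, so no number is known for compound 3. Its neighbours show what a carboxy or a hydroxy end to the chain does: compound 1 `O=C(O)CCCCCCOc1ccc2c(=O)c(-c3ccc(O)cc3)coc2c1` gives 50 nM and compound 2 `O=c1c(-c2ccc(O)cc2)coc2cc(OCCCCCCO)ccc12` gives 120 nM in this assay, while the change to the hexyl end gave an at least 180-fold higher number from compound 1 to compound 3 (2.25 log units; beyond the scatter) and an at least 75-fold higher number from compound 2 to compound 3 (1.87 log units; beyond the scatter). Compound 4 `O=c1c(-c2ccc(O)cc2)coc2cc(OCCOCCOCCO)ccc12` goes the other way: 2-(2-hydroxyethoxy)ethoxy in place of decyl on a saturated chain carbon, two bonds along the chain from an oxygen on an aromatic ring. The new chain, like that of compound 2, ends in a hydroxy group, so the step from compound 2 to compound 3 is the closest guide, read backwards, and a large drop in the number is therefore expected, about an at least 36-fold lower number from compound 3 to compound 4 (1.55 log units; beyond the scatter). Compound 4 is accordingly expected to give 250 nM in this assay, between 60 nM and 1500 nM.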

Compound 4, half-maximal inhibitory concentration: 40 nM
Compound 4: middle estimate off by 6.3-fold (0.80 log units), on the high side; the measured number lies below the stated range.
By their numbers in this assay, from the lowest: compounds 4 and 1 (each within the scatter of the next); then compound 2. At a limit, above all of these: compound 3.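

In this assay, the 2-(2-hydroxyethoxy)ethoxy chain restores inhibition lost with the decyl chain, giving an at least 220-fold lower number from compound 3 to compound 4 (2.35 log units; beyond the scatter). Compound 3 remains a limit of the assay and not a number, so this step has no known upper size: the limit of > 9000 nM in this assay, at which 1 of the 4 values shown sits. The new finding is that, among these compounds, a chain without a carboxy end can perform on a par with one that has it, with a 1.3-fold lower number from compound 1 to compound 4 (0.10 log units; within the scatter), and that replacing 4-hydroxybutyl with 2-(2-hydroxyethoxy)ethoxy gives a 3.0-fold lower number from compound 2 to compound 4 (0.48 log units; beyond the scatter).

The compounds shown leave open what an amine at the end of the chain would do, or a longer chain built from the same ethoxy units. They also do not show whether a methoxy group in place of the final hydroxy group would preserve this inhibition.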